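The source may hold more compounds than are shown below. What is called first, only, known or untested is meant among the compounds shown, and "the series" means these compounds.

Measured in a functional assay on MDA-MB-231 cells (Homo sapiens) for antiproliferative activity, read by MTT assay, with a stated time of 48 h; a higher number here means a weaker inhibitor, a lower number a stronger inhibitor:
- Compound 1 `C=CS(=O)(=O)N1CCN(c2ncnc3sc(-c4ccc(C#N)cc4)cc23)CC1`: 8050 nM
- Compound 2 `C=CS(=O)(=O)N1CCN(c2ncnc3sc(-c4ccc(N5CCN(C)CC5)cc4)cc23)CC1`: 7550 nM
- Compound 3 `C=CS(=O)(=O)N1CCN(c2nc(OC[C@H]3CCCN3C)nc3sc(-c4ccc(N5CCN(C)CC5)cc4)cc23)CC1`: 760 nM

Among these three numbers, compound 2 holds the second highest place. It lies within the scatter of compound 1 and clearly above compound 3.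

The next compound is compound 4 `CCCNC(=O)N1CCN(c2ncnc3sc(-c4ccc(N5CCN(C)CC5)cc4)cc23)CC1`, which differs from compound 2 at a single place: propylcarbamoyl in place of vinylsulfonyl on an amine nitrogen in a ring. propylcarbamoyl in place of vinylsulfonyl on an amine nitrogen in a ring

Neither measured step touches that place. All three measured compounds carry vinylsulfonyl there. The first step is a 1.1-fold lower number from compound 1 to compound 2 (0.03 log units; within the scatter), with 4-methylpiperazin-1-yl in place of cyano on an aromatic carbon. The second is a 9.9-fold lower number from compound 2 to compound 3 (1.00 log units; beyond the scatter), with (1-methylpyrrolidin-2-yl)methoxy in place of hydrogen on an aromatic carbon. Both changes are made elsewhere on the molecule, so they say little about this swap, and the data show nothing about how a change at this nitrogen acts.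

With no guide to direction, no step beyond the scatter is expected in this assay, though the uncertainty is wide. The estimate for compound 4 is 8000 nM, with an expected range of 3000 nM to 25000 nM. This estimate means an expected 1.1-fold higher number from compound 2 to compound 4 (0.03 log units; within the scatter).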

Compound 4, half-maximal inhibitory concentration: 8330 nM
The estimate for compound 4 lay 1.0-fold (0.02 log units) below the measured number, within the range that was stated.
By their numbers in this assay, from the lowest: compound 3; then compounds 2, 1 and 4 (each within the scatter of the next).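

Compound 4 is the first compound shown with a different group on this amine nitrogen, and in this assay the step reads a 1.1-fold higher number from compound 2 to compound 4 (0.04 log units; within the scatter). On this scaffold, then, vinylsulfonyl and propylcarbamoyl cannot be told apart by this read-out, even though the two groups differ in their atoms and propylcarbamoyl carries 1 hydrogen-bond donor where vinylsulfonyl has 0; vinylsulfonyl is therefore not needed for a number of this size in this pair. Nothing available here gives any independent measurement that could explain this outcome.

Going by these compounds alone, the pair covers only two groups at this nitrogen, so it remains open whether an acetyl group, a benzoyl group or a bare hydrogen there would also stay within the scatter of compound 2. Within the data shown here, it is also open whether propylcarbamoyl would read the same in the setting of compound 3, which carries (1-methylpyrrolidin-2-yl)methoxy on the core and gives 760 nM, since this swap has been seen only on a core without that group.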